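The source may report more compounds than this note shows. Statements on the series, on what has been measured and on what is new or still open speak of the compounds shown alone.

Measured so far:

compound 1, `O=C(/C=C/c1ccc(Cl)cc1Cl)c1ccccc1`, 18000 nM
compound 2, `O=C(/C(=C/c1ccccc1)CCl)c1ccccc1`, 23000 nM
compound 3, `O=C(/C(=C/c1ccc(Cl)cc1)CCl)c1ccccc1`, 22000 nM

All three numbers come from a functional assay on HeLa cells (Homo sapiens) for inhibition, read by sulforhodamine B assay, with a stated time of 48 h; a lower number here means a stronger inhibitor of growth, a higher number a weaker inhibitor of growth. Compound 2 gives 23000 nM in this assay, and that number lies within the usual scatter of both compound 1 and compound 3, so the three compounds cannot be told apart on these data.

Compound 4, `CC(=O)OC/C(=C\c1ccccc1)C(=O)c1ccccc1`, has not yet been measured. It differs from compound 2 in one place: acetoxy in place of chloro on a saturated chain carbon bound to a double-bonded chain carbon. Among the measured compounds shown here, the only measured step, from compound 2 to compound 3, touches a different part of the molecule, chloro in place of hydrogen on an aromatic carbon, and it gave a 1.0-fold lower number from compound 2 to compound 3 (0.02 log units; within the scatter). For the measured compounds named here, no measured step changes the chloromethyl group itself, so there is no direct precedent for the change to compound 4. In the absence of any step beyond the scatter, compound 4 is expected to give 20000 nM in this assay, within a range from 7000 nM to 55000 nM. That estimate means a step of a 1.2-fold lower number from compound 2 to compound 4 (0.06 log units; within the scatter), which is expected to stay within the scatter.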

Compound 4, concentration for 50% growth inhibition: 20000 nM
Compound 4: middle estimate and measured number agree at the digits printed; measured number inside the range.
By their numbers in this assay, from the lowest: compounds 1, 4, 3 and 2 (each within the scatter of the next).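

Among the compounds shown here, the earlier compounds varied only an aromatic carbon, whereas this is the first step at the saturated chain carbon bound to a double-bonded chain carbon: in this assay, acetoxy in place of chloro gives a 1.2-fold lower number from compound 2 to compound 4 (0.06 log units; within the scatter) and so leaves the growth read-out unresolved from that of the parent. In this pair, then, the chloro group is not needed for a number of this size. Acetoxy, which brings hydrogen-bond acceptors that chloro does not have, reads the same within the scatter, so chloromethyl and acetoxymethyl cannot be told apart here.

From the compounds shown here alone, whether a hydroxyl, an amine or a carboxylic acid on this same chain carbon would also stay within the scatter of compound 2 remains open. No measurement at hand accounts for why these two groups read alike.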